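The source may hold more compounds than are shown below. What is called first, only, known or untested is meant among the compounds shown, and "the series" means these compounds.

In an ADME assay on MT4 cells (Homo sapiens) for cytotoxicity, read by spectrophotometry, with a stated time of 5 days (on this read-out lower numbers stand for higher toxicity in this test and higher numbers for lower toxicity in this test), the three measured compounds stand as follows:

- compound 1, `CCn1cc(C(=O)O)c(=O)c2cc(F)c(N3CCN(CN4C(=O)/C(=N\NC(=S)NO)c5cc(C)ccc54)C(C)C3)c(F)c21`, gives 244000 nM
- compound 2, `CCn1cc(C(=O)O)c(=O)c2cc(F)c(N3CCN(CN4C(=O)/C(=N\NC(=S)NO)c5cc(Cl)ccc54)C(C)C3)c(F)c21`, gives 209000 nM
- compound 3, `CONC(=S)N/N=C1\C(=O)N(CN2CCN(c3c(F)cc4c(=O)c(C(=O)O)cn(C5CC5)c4c3OC)CC2C)c2ccc(Cl)cc21`, gives 164000 nM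

Compound 4, `CONC(=S)N/N=C1\C(=O)N(CN2CCN(c3c(F)cc4c(=O)c(C(=O)O)cn(C5CC5)c4c3OC)CC2C)c2ccc(C)cc21`, is not yet measured. It differs from compound 3 by one change, (methyl in place of chloro on an aromatic carbon). The same change, on the same kind of position, separates compound 2 from compound 1: methyl in place of chloro on an aromatic carbon. There it gave a 1.2-fold higher number from compound 2 to compound 1 (0.07 log units; within the scatter). How the core of compound 3 differs from the core of compound 2 is not broken down here; their two values in this assay lie within the scatter of each other, as do all three measured numbers.

Because a 1.2-fold higher number from compound 2 to compound 1 (0.07 log units; within the scatter) was small, the step from compound 3 to compound 4 is expected to be small as well, about a 1.2-fold higher number from compound 3 to compound 4 (0.06 log units; within the scatter). Compound 4 is therefore estimated at 190000 nM, most likely between 120000 nM and 300000 nM.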

Compound 4, half-maximal cytotoxic concentration: 154000 nM
The estimate for compound 4 lay 1.2-fold (0.09 log units) above the measured number; low and high end bracket the measured number.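

In this assay, putting methyl in place of chloro on this aromatic carbon gives a 1.1-fold lower number from compound 3 to compound 4 (0.03 log units; within the scatter). Set beside the earlier step, the change behaves alike on the two cores as far as this test can tell: the same change on two cores in this assay, a 1.2-fold higher number (0.07 log units; within the scatter) from compound 2 to compound 1 and a 1.1-fold lower number (0.03 log units; within the scatter) from compound 3 to compound 4, 1.2-fold (0.09 log units) apart, within the scatter of two such steps. This shows that the change has no readable effect on either core, but two steps this small cannot show that a larger effect would carry from one core to the other, or that the same would hold on a further core.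

The compounds shown leave open whether a different group at this place, such as an amine, a carboxylic acid or a longer chain, would give a step beyond the scatter. As far as these compounds go, whether either core would then respond as the other does also remains open.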